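The source may report more compounds than this note shows. Statements on the series, on what has been measured and on what is new or still open speak of the compounds shown alone.

Measured compounds:
Compound 1 `Cc1ccc(-c2nnc(NC(=O)CCCCCCC(=O)NO)s2)o1`: 880 nM
Compound 2 `O=C(CCCCCCC(=O)Nc1nnc(-c2cccs2)s1)NO`: 880 nM
Compound 3 `Cc1ccc2c(c1)/C(=N\O)C(=O)N2CCCC(=O)NO`: 490 nM

In a functional assay on SW-620 cells (Homo sapiens) for inhibition, read by MTT assay (on this read-out lower numbers stand for stronger inhibition and higher numbers for weaker inhibition), compound 1 stands level with compound 2 at the digits shown, and these two are together the highest of the three numbers. Compound 3 lies nearest below, with a gap that stays within the usual scatter, so none of the three can be called the stronger or weaker inhibitor on these numbers.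

Compound 4 `Cc1ccc(-c2nnc(NC(=O)CCCCCCC(=O)NO)s2)s1` is not yet measured. It differs from compound 1 in one place: 5-methylthiophen-2-yl in place of 5-methylfuran-2-yl on an aromatic carbon.

Among the compounds with values here, one measured step bears on this change. The step of no change at the digits printed from compound 1 to compound 2 (within the scatter) swapped the same five-membered ring for a close relative without the methyl group and left the number where it was. The change to compound 4 keeps the methyl group and only exchanges the ring oxygen for sulfur, so no step beyond the scatter is expected in this assay, in either direction. The estimated step of a 1.1-fold lower number from compound 1 to compound 4 (0.04 log units; within the scatter) is expected to be within the scatter. Compound 4 is expected to give about 800 nM, within a range from 400 nM to 1600 nM.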

Compound 4, half-maximal inhibitory concentration: 880 nM
Estimate against measurement, compound 4: 1.1-fold (0.04 log units) below; low and high end bracket the measured number.
By their numbers in this assay, from the lowest: compounds 3, 1, 2 and 4 (each within the scatter of the next).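

In this assay, the earlier step changed two things at once, the ring and the methyl group, so it could not show what each change did alone. The new compound separates them: exchanging the ring oxygen for sulfur with the methyl group kept gives no change at the digits printed from compound 1 to compound 4 (within the scatter), and adding the methyl group to the thiophene gives no change at the digits printed from compound 2 to compound 4 (within the scatter). Neither single change moves the number beyond the scatter, so at this place on the shared core these three rings cannot be told apart in this assay.

No measurement offered here explains this flat result. The compounds shown leave open whether a group of another kind at this place, such as a phenyl ring, an amine or a carboxylic acid on the thiophene, would shift the number.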